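The source may report more compounds than this note shows. Statements on the series, on what has been measured and on what is new or still open speak of the compounds shown alone.

Working notes on the series. In an assay on HL-60 cells for agonist activity at vitamin D3 receptor (Homo sapiens), read by microscopy, with a stated time of 96 h (on this read-out lower numbers stand for an effect already at smaller amounts and higher numbers for an effect only at larger amounts of compound), compound 1 `CCn1c(C(=O)N(C)CCC#N)ccc1C(CC)(CC)c1ccc(OCC(=O)C(C)(C)C)c(C)c1` gives 9800 nM and has the highest number of the three measured compounds; compound 3 `CCn1c(C(=O)N(C)CCC#N)ccc1C(CC)(CC)c1ccc(OCC(O)C(C)(C)C)c(C)c1` gives 1960 nM, and compound 2 `CCn1c(C(=O)NCCN(C)C)ccc1C(CC)(CC)c1ccc(OCC(O)C(C)(C)C)c(C)c1` gives 14 nM. Compound 4 `CCOC(=O)c1ccc(OC(=O)c2ccc(C(CC)(CC)c3ccc(OCC(=O)C(C)(C)C)c(C)c3)n2CC)cc1` is not yet measured; it differs from compound 1 by 4-(ethoxycarbonyl)phenoxy in place of (2-cyanoethyl)(methyl)amino on a carbonyl carbon. Within the data shown here, the only measured step at this carbonyl carbon is a 140-fold higher number from compound 2 to compound 3 (2.15 log units; beyond the scatter), which shows the position to be sensitive, while the ketone kept in compound 4 is the one that, in a 5.0-fold lower number from compound 1 to compound 3 (0.70 log units; beyond the scatter), goes with the higher numbers. Among the measured compounds shown here, no measured pair shows an ester at this carbonyl. The estimate for compound 4 therefore stays near compound 1, as a 1.6-fold lower number from compound 1 to compound 4 (0.21 log units; within the scatter), with wide bounds: compound 4 is expected at about 6000 nM, between 1000 nM and 40000 nM.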

Compound 4, half-maximal effective concentration: 45600 nM
For compound 4 the middle estimate is 7.6-fold (0.88 log units) below the measured one, outside the stated range (above it).
By their numbers in this assay, from the lowest: compound 2; then compound 3; then compound 1; then compound 4.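

In this assay, the change from the nitrile-bearing amide to an aryl ester gives a 4.7-fold higher number from compound 1 to compound 4 (0.67 log units; beyond the scatter), so the carbonyl carbon also responds to substitution when the ketone is kept, whereas the earlier step there involved only compounds carrying the 1-hydroxy-2,2-dimethylpropyl group. The larger 4-(ethoxycarbonyl)phenoxy group, with its aromatic ring and no nitrogen, brings no lower number here. Nothing available explains this step. Still open, as far as these compounds go, is how this group behaves alongside the 1-hydroxy-2,2-dimethylpropyl group, and whether a carboxylic acid in place of its ethyl ester would shift the number.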